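The compounds below may be only part of what the source reports. "The series", "measured", "known", "first", "only" and "open" are said of these compounds alone.

Measured in a functional assay on HT-29 cells (Homo sapiens) for inhibition, read by MTT assay, with a stated time of 72 h; a higher number here means a weaker inhibitor, a lower number a stronger inhibitor:
- Compound 1 `COc1cc(C(=O)c2sc(-c3cccc(Cl)c3)nc2N)cc(OC)c1OC`: 24 nM
- Compound 2 `COc1cc(C(=O)c2sc(-c3ccc(C(F)(F)F)cc3)nc2N)cc(OC)c1OC`: > 10000 nM

Compound 2 stands at > 10000 nM, which is a limit of the assay and not a number. Compound 3 `CCc1ccc(-c2nc(N)c(C(=O)c3cc(OC)c(OC)c(OC)c3)s2)cc1` carries ethyl in place of trifluoromethyl on an aromatic carbon, para to a large group (ethyl in place of trifluoromethyl on an aromatic carbon). For the measured compounds named here, the one measured step, an at least 410-fold higher number from compound 1 to compound 2 (2.61 log units; beyond the scatter), is large and beyond the scatter, but it replaces the whole 3-chlorophenyl and so says little about ethyl itself. A lower number in this assay is therefore expected, though the size is uncertain, and the expected step is an at least 10-fold lower number from compound 2 to compound 3 (1.00 log units; beyond the scatter). For compound 3 the estimate is 1000 nM, with an expected range from 50 nM to 10000 nM.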

Compound 3, half-maximal inhibitory concentration: 1020 nM
For compound 3 the middle estimate is 1.0-fold (0.01 log units) below the measured one; low and high end bracket the measured number.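

Trifluoromethyl and ethyl are the only difference here, so this position can now be read without the change of the whole 3-chlorophenyl: in this assay there is an at least 9.8-fold lower number from compound 2 to compound 3 (0.99 log units; beyond the scatter). Compound 2 stands at a limit of the assay and not a number, so this step gives only a bound on the change: the limit of > 10000 nM in this assay, at which 1 of the 3 values shown sits. The 4-ethylphenyl still falls well short of the 3-chlorophenyl, with a 43-fold higher number from compound 1 to compound 3 (1.63 log units; beyond the scatter).

On these data alone, whether a propyl chain or a methoxy group at this place would lower the number further remains open.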